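The source may hold more compounds than are shown below. What is called first, only, known or untested is meant among the compounds shown, and "the series" means these compounds.

Measured so far:
- compound 1, `CCCCCc1ccc(Nc2nc3nonc3nc2O)cc1`, 2400 nM in an assay on mitochondria from L6 cells (Rattus norvegicus) for activation, with a stated time of 90 min; a lower number here means that less compound is needed, a higher number that more compound is needed for the effect
- compound 2, `CCc1ccc(Nc2nc3nonc3nc2O)c(F)c1`, 6700 nM in this assay

Of these two numbers, compound 2 has the higher one: in this assay compound 2 gives 6700 nM, while compound 1 gives 2400 nM, a gap that lies beyond the usual scatter of repeated measurements. More of compound 2 is thus needed for the same effect than of compound 1.

The next compound to be measured is compound 3, `CCCCCc1ccc(Nc2nc3nonc3nc2O)c(F)c1`. Compared with compound 2, it differs in one place: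

propyl in place of hydrogen on a saturated chain carbon, two bonds along the chain from an aromatic carbon

Cut one bond further out, the same difference reads as ethyl to pentyl, so compound 3 carries the longer chain that compound 1 also carries, while keeping the rest of compound 2 unchanged. Going by the values given here, no step between two measured compounds describes this exact change, so the expectation rests only on the two numbers known.

Compound 3 is expected to need somewhat less compound than compound 2 because compound 1 with its pentyl chain gives 2400 nM. The estimated step of a 2.2-fold lower number from compound 2 to compound 3 (0.35 log units; beyond the scatter) would take compound 3 below compound 2, by a margin that could be beyond the scatter but is uncertain. The estimate for compound 3 in this assay is 3000 nM, within a range from 1000 nM to 9000 nM.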

Compound 3, half-maximal effective concentration: 1500 nM
The estimate for compound 3 lay 2.0-fold (0.30 log units) above the measured number; the range from low to high includes it.
By their numbers in this assay, from the lowest: compounds 3 and 1 (each within the scatter of the next); then compound 2.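

Holding everything else in place and lengthening the chain from ethyl to pentyl gives a 4.5-fold lower number from compound 2 to compound 3 (0.65 log units; beyond the scatter) in this assay, which makes this chain the first place in the series where a single change is seen to shift the number clearly. The fluoro behaves differently: with the pentyl chain already present, fluoro in place of hydrogen on an aromatic carbon gives a 1.6-fold lower number from compound 1 to compound 3 (0.20 log units; within the scatter), so compound 1 and compound 3 cannot be told apart, and the two together suggest that, among these compounds, the chain length counts for more than this fluoro. Nothing available here explains why the longer chain goes with a lower number.

The compounds shown leave open whether a still longer chain, such as octyl, would take the number lower, or whether a pentyl chain ending in a carboxylic acid or an amine would keep it there. Going by these compounds alone, they also leave open whether the fluoro would make a larger difference on the ethyl chain, as its only pair here carries pentyl.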